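The source may report more compounds than this note shows. Statements on the series, on what has been measured and on what is new or still open speak of the compounds shown alone.

Measured in a functional assay on ASPC1 cells (Homo sapiens) for antiproliferative activity, read by MTT assay, with a stated time of 72 h; a higher number here means a weaker inhibitor, a lower number a stronger inhibitor:
- Compound 1 `C=CC(=O)Nc1cc(Nc2nccc(NC(=O)c3cccc(OC)c3)n2)c(OC)cc1N1CCN(C)CC1`: > 10000 nM, a limit of the assay and not a number
- Compound 2 `C=CC(=O)Nc1cc(Nc2nccc(NC(=O)c3ccc(C(F)(F)F)cc3)n2)c(OC)cc1N1CCN(C)CC1`: > 10000 nM, a limit of the assay and not a number
- Compound 3 `C=CC(=O)Nc1cc(Nc2nccc(NC(=O)c3cccc(OC)c3)n2)c(OC)cc1N(C)CCN(C)C`: 3400 nM

Compound 3 is the only one of the three with an actual number, so it has no measured neighbour to be ranked against exactly. The other two show (the limit of > 10000 nM in this assay, at which 2 of the 3 values shown sit).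

Compound 4 `C=CC(=O)Nc1cc(Nc2nccc(NC(=O)c3ccccc3)n2)c(OC)cc1N(C)CCN(C)C` changes compound 3 in one place, with hydrogen in place of methoxy on an aromatic carbon, meta to a large group: hydrogen in place of methoxy on an aromatic carbon.

Among the compounds with values here, no measured step isolates this change. The nearest is a step that the two limits leave unreadable from compound 1 to compound 2, which alters the same aromatic group but cannot be sized. Within the data shown here, the one step with a readable size is an at least 2.9-fold lower number from compound 1 to compound 3 (0.46 log units; beyond the scatter), and it concerns the (2-(dimethylamino)ethyl)(methyl)amino group, which compound 4 keeps. With no evidence for a direction, the expectation in this assay is no shift beyond the scatter, though with wide uncertainty.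

The expected change is a 1.0-fold higher number from compound 3 to compound 4 (0.01 log units; within the scatter).

Compound 4 is estimated at 3500 nM, with an expected range from 1200 nM to 10000 nM.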

Compound 4, half-maximal inhibitory concentration: 3580 nM
Estimate against measurement, compound 4: 1.0-fold (0.01 log units) below, and the stated range covers the measured number.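

In this assay, replacing the methoxy group with hydrogen gives a 1.1-fold higher number from compound 3 to compound 4 (0.02 log units; within the scatter), so the two compounds cannot be told apart. Within the data shown here, this is the first readable result for a change on this aromatic ring, since the earlier change there, between compound 1 and compound 2, cannot be read because both compounds sit at a limit of the assay: the limit of > 10000 nM in this assay, at which 2 of the 4 values shown sit. With the (2-(dimethylamino)ethyl)(methyl)amino group in place, this pair shows that the methoxy group is not required at this position to keep the activity seen in compound 3.

From the compounds shown here alone, whether an amine, a carboxylic acid or a fluorine atom at this position would shift the number remains open. Also open, going by these compounds, is whether swapping methoxy for hydrogen would have the same outcome in a compound carrying the 4-methylpiperazin-1-yl group.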